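The compounds below may be only part of what the source reports. "The series", "measured", "known", "first", "only" and "open" are said of these compounds alone.

Measured so far in a functional assay on NCI-H1581 cells (Homo sapiens) for antiproliferative activity, read by CCK-8 assay, with a stated time of 72 h; on this read-out higher numbers stand for weaker inhibition and lower numbers for stronger inhibition:
compound 1, `COc1cc(OC)c(Cl)c(-c2ccc3c(NC(=O)c4ccc(C5CCN(C)CC5)cc4)n[nH]c3n2)c1Cl` — 8.2 nM
compound 2, `CCN1CCN(c2ccc(C(=O)Nc3n[nH]c4nc(-c5c(Cl)c(OC)cc(OC)c5Cl)ccc34)cc2)CC1` — 0.7 nM
compound 3, `C=CCN1CCN(c2ccc(C(=O)Nc3n[nH]c4nc(-c5c(Cl)c(OC)cc(OC)c5Cl)ccc34)cc2)CC1` — 3.3 nM

Compound 2 gives the lowest of the three numbers in this assay, with a 4.7-fold higher number from compound 2 to compound 3 (0.67 log units; beyond the scatter) and, in the other direction, a 12-fold lower number from compound 1 to compound 2 (1.07 log units; beyond the scatter); both gaps lie beyond the scatter. Compound 3 in turn sits below compound 1 by a 2.5-fold lower number from compound 1 to compound 3 (0.40 log units; beyond the scatter).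

Compound 4, `COc1cc(OC)c(Cl)c(-c2ccc3c(NC(=O)c4ccc(N5CCN(S(C)(=O)=O)CC5)cc4)n[nH]c3n2)c1Cl`, differs from compound 2 in one place: methylsulfonyl in place of ethyl on an amine nitrogen in a ring. Among the compounds with values here, the only measured step at the same ring nitrogen is the one from compound 2 to compound 3, where a change on the saturated chain carbon bound to that nitrogen gave a 4.7-fold higher number from compound 2 to compound 3 (0.67 log units; beyond the scatter). Within the data shown here, no measured step replaces the ethyl with a methylsulfonyl, so nothing here fixes the direction for compound 4. Two of the three compounds changed at this end of the molecule gave higher numbers than compound 2, and compound 2 is the lowest value seen, which leaves more room upward than downward. For compound 4 a modest step to a higher number is therefore expected, an 11-fold higher number from compound 2 to compound 4 (1.06 log units; beyond the scatter), with the estimate for compound 4 in this assay put at 8 nM, within a range from 2 nM to 40 nM.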

Compound 4, half-maximal inhibitory concentration: 245 nM
Compound 4: middle estimate off by 31-fold (1.49 log units), on the low side; measured number above the stated range.
By their numbers in this assay, from the lowest: compound 2; then compound 3; then compound 1; then compound 4.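

In this assay, the two chains seen earlier on the amine nitrogen in a ring, ethyl and allyl, differed only modestly, with a 4.7-fold higher number from compound 2 to compound 3 (0.67 log units; beyond the scatter), whereas methylsulfonyl at the same nitrogen gives much larger steps: a 350-fold higher number from compound 2 to compound 4 (2.54 log units; beyond the scatter) and a 74-fold higher number from compound 3 to compound 4 (1.87 log units; beyond the scatter). Keeping the six-membered ring with 2 nitrogen is therefore not enough, as the order relative to the 1-methylpiperidin-4-yl group reverses, with a 30-fold higher number from compound 1 to compound 4 (1.48 log units; beyond the scatter), while the ethyl and allyl compounds both gave lower numbers than that group. The change brings 2 hydrogen-bond acceptors and 2 double bonds outside aromatic rings, but no available evidence links the loss of activity to either count or to any other feature of the group.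

The compounds shown leave open whether the large rise is specific to methylsulfonyl or would also follow an acetyl group, a 2-hydroxyethyl chain or a free amine hydrogen at this nitrogen. Also open, going by these compounds, is whether a methyl or propyl group there would track closer to ethyl or to allyl.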